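Methyl in Place of Chloro on the Aryl Ring

The source may hold more compounds than are shown below. What is called first, only, known or untested is meant among the compounds shown, and "the series" means these compounds.

In a functional assay on MDA-MB-435 cells (Homo sapiens) for antiproliferative activity (a higher number here means a weaker inhibitor of growth, a lower number a stronger inhibitor of growth), compound 1 `Cc1cc(C)c2c(O)cc(-c3cccc4ccccc34)nc2n1` gives 191 nM. Compound 2 `Cc1cccc(-c2cc(O)c3cc(C)cnc3n2)c1` returns only a limit of the assay in this assay, < 10 nM. Compound 3 `Cc1ccc2c(O)cc(-c3cccc(Cl)c3)nc2n1` likewise sits at a limit in this assay, < 10 nM. Two of the three values shown rest at the limit of < 10 nM in this assay, at which 2 of the 3 values shown sit. Compound 4 `Cc1cccc(-c2cc(O)c3ccc(C)nc3n2)c1` differs from compound 3 by methyl in place of chloro on an aromatic carbon. For the measured compounds named here, no measured step between two compounds here covers this exchange, so the size of the step in this assay can only be judged from the neighbours; compound 2, which also carries a methyl on that ring, stands at a limit as well. Compound 4 is expected to remain potent, with the step that the limit leaves unreadable from compound 3 to compound 4 estimated to lie within the scatter. Compound 4 is estimated at 8 nM, between 2 nM and 30 nM.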

Compound 4, concentration for 50% growth inhibition: 32.4 nM
Compound 4: middle estimate off by 4.1-fold (0.61 log units), on the low side; the whole stated range lies below it.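

In this assay, methyl in place of chloro on an aromatic carbon, meta to a large group, gives an at least 3.2-fold higher number from compound 3 to compound 4 (0.51 log units; beyond the scatter). The earlier compounds shown here offered no step at all, and this first one shows that this position responds to the exchange of a single heavy atom. Compound 3 stands at a limit of the assay, so the step gives only a lower bound on the size of the change: the limit of < 10 nM in this assay, at which 2 of the 4 values shown sit.

As far as these compounds go, how far the true gap exceeds that bound remains open. So does where an amine or a methoxy group at this position would fall relative to chloro and methyl.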